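A few compounds are considered here, and "the series" means these few. Any claim that something is new, unique, unknown or untested is made for them only; others in the source may bear on it.

Measured compounds:
- Compound 1 `COc1cc(-c2nnc(SCC(=O)c3ccc(C)cc3)n2N)cc(OC)c1OC` gives > 100000 nM in a functional assay on HepG2 cells (Homo sapiens) for antiproliferative activity, read by MTT assay, with a stated time of 48 h; on this read-out lower numbers stand for stronger inhibition and higher numbers for weaker inhibition; this is a limit of the assay, not a number.
- Compound 2 `COc1cc(-c2nnc(SCC(=O)c3ccc(F)c(F)c3)n2N)cc(OC)c1OC` gives > 100000 nM in this assay; again a limit of the assay.
- Compound 3 `COc1ccc(C(=O)CSc2nnc(-c3cc(OC)c(OC)c(OC)c3)n2N)cc1` gives > 100000 nM in this assay; again a limit of the assay.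

Compound 1 therefore stands at the limit of this assay, with no number attached; the same holds for the other two values shown, so the limit of > 100000 nM in this assay, at which 3 of the 3 values shown sit, summarises the whole measured set. The steps between them, a step that the two limits leave unreadable from compound 1 to compound 2, a step that the two limits leave unreadable from compound 1 to compound 3 and a step that the two limits leave unreadable from compound 2 to compound 3, are all unreadable, since both ends of each step are limits.

Compound 4 `COc1cc(-c2nnc(SCC(=O)Nc3ccccc3)n2N)cc(OC)c1OC` is not yet measured in this assay. It differs from compound 1 as anilino in place of 4-methylphenyl on a carbonyl carbon, the change being cut one bond further out as (4-methylphenyl)carbonyl to phenylcarbamoyl. Within the data shown here, none of the measured steps bears on this change: all three steps leave the exchanges on the carbonyl carbon unread, and no compound carrying an anilino group on that carbon has been measured. With the three measured values all sitting at the limit, the step of a number no higher from compound 1 to compound 4 (the limit leaves the size open) is expected to stay within the scatter, and compound 4 is estimated at 100000 nM, within 30000 nM to 300000 nM, most likely reported again only as a limit.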

Compound 4, half-maximal inhibitory concentration: 49900 nM
For compound 4 the middle estimate is 2.0-fold (0.30 log units) above the measured one; the measured number falls inside the stated range.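

On the carbonyl carbon, anilino gives the first result in this assay that is a number and not a limit, which 4-methylphenyl in compound 1, 3,4-difluorophenyl in compound 2 and 4-methoxyphenyl in compound 3 did not give: the limit of > 100000 nM in this assay, at which 3 of the 4 values shown sit. From the compounds shown here alone, the change reads as an at least 2.0-fold lower number from compound 1 to compound 4 (0.30 log units; that floor lies within the scatter), as an at least 2.0-fold lower number from compound 2 to compound 4 (0.30 log units; that floor lies within the scatter) and as an at least 2.0-fold lower number from compound 3 to compound 4 (0.30 log units; that floor lies within the scatter), so each step is only a floor set by a limit at one end, and its true size stays open. Anilino and 4-methylphenyl have the same heavy-atom count and the same ring, so in the step from compound 1 the counted differences are the nitrogen and the hydrogen-bond donor it brings, though one compound cannot show that these decide the result.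

The steps among compound 1, compound 2 and compound 3 cannot be read, so the three groups they carry cannot be ranked against one another. Open as well is how the number responds to a methyl, methoxy or fluorine on the anilino ring, or to a benzylamino or cyclohexylamino group on the same carbonyl carbon.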